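The source may hold more compounds than are shown below. What is called first, only, known or untested is meant among the compounds shown, and "the series" means these compounds.

Compound 1 `CCOC(=O)c1c(-c2cc(F)cc(OC)c2)[nH]c2cc(OC)ccc2c1=O`: > 22000 nM
Compound 2 `CCOC(=O)c1c(-c2cccc(Oc3ccccc3)c2)[nH]c2cc(OC)ccc2c1=O`: > 22000 nM
Compound 3 `CCOC(=O)c1c(-c2cccc(Cl)c2)[nH]c2cc(OC)ccc2c1=O`: > 22000 nM

All three entries are limits of the assay and not numbers. They come from an ADME assay on HEK293 cells (Homo sapiens) for cytotoxicity, read by luminescence, with a stated time of 72 h; on this read-out higher numbers stand for an effect only at larger amounts of compound and lower numbers for an effect already at smaller amounts.

In this assay compound 3 gives > 22000 nM. That is a limit, so compound 3 has no exact place on the scale.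

The next compound, compound 4 `CCOC(=O)c1c(-c2cccc([N+](=O)[O-])c2)[nH]c2cc(OC)ccc2c1=O`, keeps the shared core and changes one group: nitro in place of chloro on an aromatic carbon. In words, this is nitro in place of chloro on an aromatic carbon, turning 3-chlorophenyl into 3-nitrophenyl.

Two measured steps also end at compound 3 and change the group on this same ring. Within the data shown here, the first is a step that the two limits leave unreadable from compound 1 to compound 3, with 3-chlorophenyl in place of 3-fluoro-5-methoxyphenyl. The second is a step that the two limits leave unreadable from compound 2 to compound 3, with chloro in place of phenoxy.

Neither step has a size that can be carried over. Compound 1, compound 2 and compound 3 all share (the limit of > 22000 nM in this assay, at which 3 of the 3 values shown sit), so none of these groups has yet produced a number.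

The expected change is therefore a number no higher from compound 3 to compound 4 (the limit leaves the size open), with no step beyond the scatter and no direction expected.

Compound 4 is estimated at 22000 nM, with an expected range from 10000 nM to 40000 nM, and most likely only a limit will be reported.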

Compound 4, half-maximal effective concentration: > 22000 nM
Compound 4: a limit, no number; the forecaster's own chance of this, stated with the estimate: 80%; the middle value sits exactly at the limit.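

In this assay compound 4 gives > 22000 nM, a limit and not a number, so its steps from compound 1, compound 2 and compound 3 cannot be read. The compounds shown leave open whether any of these groups would give an actual number, and how the groups would then compare: the limit of > 22000 nM in this assay, at which 4 of the 4 values shown sit.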